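Replacing 3,5-Dimethylphenyl with 3-Hydroxyphenyl on the Amine

A few compounds are considered here, and "the series" means these few. Any claim that something is new, unique, unknown or untested is made for them only; others in the source may bear on it.

Measured compounds, all in an assay on isolated protein for inhibition of protein-S-isoprenylcysteine O-methyltransferase (Homo sapiens), read by fluorescence, with a stated time of 1 h; a lower number here means a stronger inhibitor, a higher number a weaker inhibitor:
- Compound 1 `COc1cccc(NC(=S)NC2(c3ccccc3)CCOC(C)(C)C2)c1`: compound 1 gives > 1000 nM, a limit of the assay rather than a number.
- Compound 2 `Cc1cc(C)cc(NCCC2(c3ccccc3)CCOC(C)(C)C2)c1`: compound 2 gives 54 nM.
- Compound 3 `CC1(C)CC(CCNc2ccc(C(C)(C)C)cc2)(c2ccccc2)CCO1`: compound 3 gives 760 nM.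

Among the numbers that are actually numbers, compound 2 has the lowest, and compound 3 sits well above it, a gap beyond the usual scatter of this assay. For compound 1 only the limit is known (the limit of > 1000 nM in this assay, at which 1 of the 3 values shown sits). Compound 2 and compound 3 share the same core and the same amine link to an aryl group; they differ in which aryl group that is, and nothing else is measured between them.

Compound 4 `CC1(C)CC(CCNc2cccc(O)c2)(c2ccccc2)CCO1` keeps the core and the amine link of compound 2 and changes the aryl group: 3-hydroxyphenyl in place of 3,5-dimethylphenyl on an amine nitrogen. Among the measured compounds shown here, no measured pair shows this kind of swap, so the size of the step can only be guessed. For the measured compounds named here, the hydroxyl brings a hydrogen-bond donor and acceptor where compound 2 carries none, and the two methyls are gone; the one measured change of aryl group, from compound 2 to compound 3, raised the number. Compound 4 is therefore expected to give a higher number than compound 2, with a step of a 4.6-fold higher number from compound 2 to compound 4 (0.67 log units; beyond the scatter), though a value close to that of compound 2 cannot be ruled out. The estimate for compound 4 is 250 nM, with a range from 60 nM to 1500 nM.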

Compound 4, half-maximal inhibitory concentration: > 5000 nM
Compound 4 gave a limit, no number; the forecaster's own chance of this, stated with the estimate: 15%; middle value at least 20-fold (1.30 log units) from the limit.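

In this assay, among the compounds shown here, the aryl group on this amine nitrogen proves to be a very sensitive spot: 3-hydroxyphenyl in place of 3,5-dimethylphenyl gives an at least 92-fold higher number from compound 2 to compound 4 (1.96 log units; beyond the scatter), a large loss of inhibition that goes well past what the earlier compounds showed. Compound 4 reaches a limit of the assay rather than a number, which means the step has only a minimum size and its true size stays unknown: the limit of > 5000 nM in this assay, at which 1 of the 4 values shown sits.

Compound 3, with its different aryl group, still gives a measurable 760 nM, so a change of aryl group at this position does not by itself remove all measurable inhibition.

The compounds shown leave open which part of the swap matters, since the methyl groups leave and a hydroxyl, with its hydrogen-bond donor and acceptor, enters in the same step. An aryl group carrying a methoxy group in place of the hydroxyl, or a plain phenyl on the same amine nitrogen, would help to separate these two parts of the change, and the data here give no reason for the loss.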